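This account rests on a few compounds, and the source may have more. Where it says the series, first, only, none or still open, it means among the compounds named here.

Measured so far in an assay for inhibition of 3-hydroxy-3-methylglutaryl-coenzyme A reductase (Rattus norvegicus); on this read-out lower numbers stand for stronger inhibition and higher numbers for weaker inhibition:
Compound 1 `O=C1C[C@H](O)C[C@@H](/C=C/c2c(Cl)cc(Cl)cc2-c2cc(Cl)cc(Cl)c2)O1` gives 37 nM.
Compound 2 `COc1ccc(-c2cc(Cl)cc(Cl)c2/C=C/[C@@H]2C[C@@H](O)CC(=O)O2)cc1` gives 470 nM.
Compound 3 `Cc1cc(C)cc(-c2cc(Cl)cc(Cl)c2/C=C/[C@@H]2C[C@@H](O)CC(=O)O2)c1` gives 13 nM.

Compound 1 stands second highest of the three numbers: compound 3 lies a 2.8-fold lower number from compound 1 to compound 3 (0.45 log units; beyond the scatter), and compound 2 lies a 13-fold higher number from compound 1 to compound 2 (1.10 log units; beyond the scatter). Compound 4 `Cc1ccc(-c2cc(Cl)cc(Cl)c2/C=C/[C@@H]2C[C@@H](O)CC(=O)O2)cc1` has not been measured. It differs from compound 1 by 4-methylphenyl in place of 3,5-dichlorophenyl on an aromatic carbon. Within the data shown here, two measured steps bear on this change. Swapping the 3,5-dichlorophenyl for a 3,5-dimethylphenyl gave a 2.8-fold lower number from compound 1 to compound 3 (0.45 log units; beyond the scatter), a modest gain; swapping it for a 4-methoxyphenyl gave a 13-fold higher number from compound 1 to compound 2 (1.10 log units; beyond the scatter), a large loss. A 4-methylphenyl keeps the carbon-only ring without the two chloro groups, sitting between these two cases, so little change beyond the scatter is expected. Compound 4 is therefore estimated at 55 nM, ranging from 15 nM to 200 nM, a step of a 1.5-fold higher number from compound 1 to compound 4 (0.17 log units; within the scatter) in this assay.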

Compound 4, half-maximal inhibitory concentration: 190 nM
Compound 4: the middle estimate sits 3.5-fold (0.54 log units) below what was measured; the measured number falls inside the stated range.
By their numbers in this assay, from the lowest: compound 3; then compound 1; then compound 4; then compound 2.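

The 4-methylphenyl ring costs activity relative to the 3,5-dichlorophenyl ring (a 5.1-fold higher number from compound 1 to compound 4 (0.71 log units; beyond the scatter)), so a carbon-only ring carrying methyl in place of chloro groups does not by itself keep the activity. The loss against the 3,5-dimethylphenyl ring is larger (a 15-fold higher number from compound 3 to compound 4 (1.16 log units; beyond the scatter)), so these two methyl-bearing rings are far from interchangeable at this place. Methyl in place of methoxy recovers only part of the gap (a 2.5-fold lower number from compound 2 to compound 4 (0.39 log units; beyond the scatter)), leaving compound 2 and compound 4 both weaker than compound 1 and compound 3. Nothing available gives a cause for these steps. As far as these compounds go, how a plain phenyl or a 3-methylphenyl ring would compare remains open.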